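This account rests on a few compounds, and the source may have more. Where it says the series, first, only, none or still open, it means among the compounds named here.

In a functional assay on CCRF-CEM cells (Homo sapiens) for antiproliferative activity, with a stated time of 72 h (on this read-out higher numbers stand for an effect only at larger amounts of compound and lower numbers for an effect already at smaller amounts), compound 2 (`Cc1cn([C@H]2C[C@H](CF)[C@@H](CO)O2)c(=O)[nH]c1=O`) gives > 100 uM as a limit of the assay, not a number. Compound 1 (`Cc1cn([C@@H]2O[C@H](CO)[C@@H](CN=[N+]=[N-])[C@@H]2O)c(=O)[nH]c1=O`) gives > 100 uM as a limit too. Compound 3 (`Cc1cn([C@@H]2O[C@H](CO)[C@@H](CO)[C@@H]2O)c(=O)[nH]c1=O`) gives > 100 uM as a limit as well. All the data so far therefore sit at the same limit (the limit of > 100 uM in this assay, at which 3 of the 3 values shown sit). Compound 4 (`Cc1cn([C@H]2C[C@H](CN)[C@@H](CO)O2)c(=O)[nH]c1=O`) differs from compound 2 by amino in place of fluoro on a saturated chain carbon bound to a saturated ring carbon in one change, amino in place of fluoro on a saturated chain carbon bound to a saturated ring carbon. Going by the values given here, the only measured step (a step that the two limits leave unreadable from compound 1 to compound 3) also swaps a group on such a carbon, but it offers no size to carry over, so no step beyond the scatter is expected in this assay in either direction. The expected step is a step that the limit leaves unreadable from compound 2 to compound 4 and no larger. Compound 4 is estimated at 120 uM with a range from 50 uM to 300 uM and may well prove to sit at a limit of the assay too.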

Compound 4, concentration for half-maximal effect: > 100 uM
Compound 4: a limit, no number (the forecaster's own chance of this, stated with the estimate: 80%); the middle value is on the limit's open side.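

Going by these compounds alone, compound 2 and compound 4 each give only a limit, not a number, so no step between them can be read in this assay. The compounds shown leave open whether any one differs from another, since all share one limit: the limit of > 100 uM in this assay, at which 4 of the 4 values shown sit.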